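A few compounds are considered here, and "the series" means these few. Any claim that something is new, unique, unknown or untested is made for them only; others in the source may bear on it.

Of the compounds shown here, three built on one shared core have been measured in a functional assay on A-375 cells (Homo sapiens) for antiproliferative activity, read by CCK-8 assay, with a stated time of 72 h, tested at 2 uM; on this read-out higher numbers stand for a stronger effect at the one concentration tested and lower numbers for a weaker effect. Compound 1 `Nc1ccccc1NC(=O)c1ccc(CSC(=S)N2CCN(c3ccccc3)CC2)cc1` gives 27.5%. Compound 2 `Nc1ccccc1NC(=O)c1ccc(CSC(=S)N2CCc3cc(Cl)ccc32)cc1` gives 31.9%, which is the largest of the three numbers, and compound 3 `Nc1ccccc1NC(=O)c1ccc(CSC(=S)N2CCN(c3ncccn3)CC2)cc1` gives 24%; the gaps from compound 2 to the other two lie within the scatter, so no order among the three can be read from these values. For the measured compounds named here, the one step that changes a single place, a number 3.5 percentage points lower from compound 1 to compound 3 (within the scatter), likewise stays within the scatter. Compound 4 `Nc1ccccc1NC(=O)c1ccc(CSC(=S)N2CCCC2)cc1` has not yet been measured; it differs from compound 2 by pyrrolidin-1-yl in place of 5-chloro-2,3-dihydro-1H-indol-1-yl on a thiocarbonyl carbon. Going by the values given here, no measured step touches the group on the thiocarbonyl carbon, so the only guidance is that the three measured compounds sit close together and that the step from compound 1 to compound 3 stayed small. Among the compounds with values here, a step of a number 7.9 percentage points lower from compound 2 to compound 4 (within the scatter) in this assay is therefore expected, with the caution that no direct precedent exists for this exchange. Compound 4 is estimated at 24%, between 10% and 38%.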

Compound 4, a percentage reported as inhibition, at one concentration (the size of the read-out at that concentration, not a potency): 30.2%
Compound 4: the middle estimate sits 6.2 percentage points below what was measured, and the stated range covers the measured number.
By their numbers in this assay, from the lowest: compounds 3, 1, 4 and 2 (each within the scatter of the next).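

In this assay, the exchange of 5-chloro-2,3-dihydro-1H-indol-1-yl for pyrrolidin-1-yl on a thiocarbonyl carbon is a step of a number 1.7 percentage points lower from compound 2 to compound 4 (within the scatter). For the compounds shown here, this is the first measured step at this place, and it shows that the six-membered aromatic ring and the chlorine can both go from the group without the read-out separating the two compounds. Nothing measured on the compounds offers an account of this result.

Going by these compounds, it remains open whether a smaller open-chain dimethylamino group or a morpholin-4-yl group on the thiocarbonyl carbon would also leave the number within the scatter of compound 2 and compound 4. With only one concentration tested, the read-out also leaves open whether compound 2 and compound 4 would differ in potency.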